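From fluoro to amino on a shared core

A few compounds are considered here, and "the series" means these few. Any claim that something is new, unique, unknown or untested is made for them only; others in the source may bear on it.

Compound 1 `Cc1nc(N)nc2c1c(-c1ccc3oc(N)nc3c1)nn2C(C)C` gives 74000 nM in a physicochemical assay for solubility, read by HPLC, in phosphate buffer, measured as kinetic solubility, with a stated time of 24 h, at 20 degrees C, at pH 7.4, tested at 100 uM; on this read-out higher numbers stand for higher solubility and lower numbers for lower solubility.
Compound 2 `CC(C)n1nc(-c2ccc3oc(N)nc3c2)c2c(CO)nc(N)nc21` gives 82000 nM in this assay.
Compound 3 `CC(C)n1nc(-c2ccc3oc(N)nc3c2)c2c(F)nc(N)nc21` reaches only a limit of the assay, < 1000 nM, in this assay.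

Compound 3 thus stands lowest of the three, known only through (the limit of < 1000 nM in this assay, at which 1 of the 3 values shown sits). Compound 4 `CC(C)n1nc(-c2ccc3oc(N)nc3c2)c2c(N)nc(N)nc21` differs from it by amino in place of fluoro on an aromatic carbon. The measured steps that touch this position are an at least 74-fold lower number from compound 1 to compound 3 (1.86 log units; beyond the scatter) and an at least 82-fold lower number from compound 2 to compound 3 (1.91 log units; beyond the scatter), both large drops on arriving at fluoro. Neither step involves an amino group, and the size of the move away from fluoro is therefore uncertain. A rise beyond the scatter is nevertheless expected for compound 4, an at least 30-fold higher number from compound 3 to compound 4 (1.47 log units; beyond the scatter). Compound 4 is estimated at 30000 nM, between 4000 nM and 90000 nM.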

Compound 4, solubility: 88000 nM
Beside the measured number, compound 4's estimate is 2.9-fold (0.47 log units) below it; low and high end bracket the measured number.
By their numbers in this assay, from the lowest: compounds 1, 2 and 4 (each within the scatter of the next). At a limit, below all of these: compound 3.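

In this assay, amino in place of fluoro gives an at least 88-fold higher number from compound 3 to compound 4 (1.94 log units; beyond the scatter). That size is only a bound, since compound 3 stands at a limit of the assay: the limit of < 1000 nM in this assay, at which 1 of the 4 values shown sits. Amino sits level with the other two groups, with a 1.1-fold higher number from compound 2 to compound 4 (0.03 log units; within the scatter) and a 1.2-fold higher number from compound 1 to compound 4 (0.08 log units; within the scatter), so among the four groups shown, fluoro alone stands apart at this position.

Still open, going by these compounds, is how a substituted amine such as dimethylamino, or a methoxy group, would read at this position. Also open, on these data alone, is whether chloro, another halogen, would drop as fluoro does.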